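The compounds below may be only part of what the source reports. "The series", "measured", "known", "first", "only" and "open" are said of these compounds alone.

For the measured compounds named here, in a functional assay on PANC-1 cells (Homo sapiens) for cytotoxicity, read by MTT assay, with a stated time of 72 h (a lower number here means a stronger inhibitor, a higher number a weaker inhibitor), compound 1 `CN1C/C(=C\c2ccccc2F)C(=O)/C(=C/c2ccccc2F)C1` gives 2200 nM and so holds one of only two true numbers in this small set. Sharing its core, compound 2 `CN1C/C(=C\c2ccc(F)c(F)c2)C(=O)/C(=C/c2ccc(F)c(F)c2)C1` gives 1500 nM, which lies within the usual scatter of the number for compound 1. Compound 3 `CN1C/C(=C\c2c(F)cc(F)cc2F)C(=O)/C(=C/c2c(F)cc(F)cc2F)C1` reads > 10000 nM, which is a limit of the assay and not a number.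

Compound 4 `CCN1C/C(=C\c2ccccc2F)C(=O)/C(=C/c2ccccc2F)C1` differs from compound 1 in one place methyl in place of hydrogen on a saturated chain carbon bound to an amine nitrogen in a ring, which also reads as methyl to ethyl. Going by the values given here, no measured pair here tests this change, so the expectation rests on compound 1 at 2200 nM and on how small the change is. In this assay, the expected step of a 1.1-fold lower number from compound 1 to compound 4 (0.04 log units; within the scatter) stays within the scatter, with neither direction favoured. The estimate for compound 4 is 2000 nM, with an expected range from 800 nM to 5000 nM.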

Compound 4, half-maximal inhibitory concentration: 1700 nM
Compound 4: middle estimate off by 1.2-fold (0.07 log units), on the high side; measured number inside the range.
By their numbers in this assay, from the lowest: compounds 2, 4 and 1 (each within the scatter of the next). At a limit, above all of these: compound 3.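

Until now, compound 1, compound 2 and compound 3 all carried the same methyl group at this place, so they showed nothing about changing it. In this assay, the change from methyl to ethyl gives a 1.3-fold lower number from compound 1 to compound 4 (0.11 log units; within the scatter), so at this place the added carbon leaves no change that can be told from ordinary repeat-to-repeat variation. Nothing measured here speaks to a cause for this small step.

From the compounds shown here alone, a longer chain such as propyl, a benzyl group or a carboxylic acid at this place remains open, and one such group could tell whether the room for change reaches beyond ethyl. Going by these compounds, it is also open whether ethyl would give a similarly small step on the core of compound 2 or compound 3.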